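An Amide Substituent Swap in a Cytotoxicity Series

The source may hold more compounds than are shown below. What is called first, only, known or untested is meant among the compounds shown, and "the series" means these compounds.

Of the compounds shown here, two have so far been tested in a functional assay on HepG2 cells (Homo sapiens) for cytotoxicity, read by sulforhodamine B assay, with a stated time of 48 h; on this read-out higher numbers stand for weaker inhibition of growth and lower numbers for stronger inhibition of growth. Compound 1 `CCCCC1=NC2(CCCC2)C(=O)N1C(=O)COc1ccc(/C=C2/SC(=O)NC2=O)cc1` gives < 100000 nM in this assay, which is a limit of the assay rather than a number. Compound 2 `O=C(COc1ccc(/C=C2\SC(=O)NC2=O)cc1)Nc1nc2ccccc2s1` likewise gives < 100000 nM in this assay, again a limit of the assay. For the measured compounds named here, compound 2 thus stands where every value seen so far stands: the limit of < 100000 nM in this assay, at which 2 of the 2 values shown sit, and no step between measured compounds exists to show how any change moves the read-out. Compound 3 `Cc1cc(NC(=O)COc2ccc(/C=C3\SC(=O)NC3=O)cc2)no1` is the next compound, and it differs from compound 2 in one place: 5-methyl-1,2-oxazol-3-yl in place of 1,3-benzothiazol-2-yl on an amide-type nitrogen. With both known values sitting at a limit, no direction can be read for this change, and it is expected to give a step that the limit leaves unreadable from compound 2 to compound 3, none beyond the scatter. Compound 3 is accordingly estimated at 50000 nM in this assay, with a likely range from 10000 nM to 100000 nM, and the result may well again be reported only as a limit.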

Compound 3, concentration for total growth inhibition: < 100000 nM
Compound 3: only a limit was reported (the forecaster's own chance of this, stated with the estimate: 70%); the middle value is on the limit's open side.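

No step can be read from compound 2 to compound 3, because each is reported only as a limit and not as a number: the limit of < 100000 nM in this assay, at which 3 of the 3 values shown sit. The compounds shown leave open how strongly each inhibits growth in this assay, and whether 5-methyl-1,2-oxazol-3-yl and 1,3-benzothiazol-2-yl differ there at all.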